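Cyclopropyl for Methyl on Two Related Amide Cores

The source may hold more compounds than are shown below. What is called first, only, known or untested is meant among the compounds shown, and "the series" means these compounds.

The study compares four compounds that share a pyrrolidine carboxamide bearing a chloro and trifluoromethyl substituted anilide, joined to a triazole that carries either a pyridine or a fused bicyclic head group. Compound 1 `CC(=O)Nc1ccc(-c2cn([C@@H]3CN[C@H](C(=O)Nc4ccc(Cl)c(C(F)(F)F)c4)C3)nn2)cn1` is the acetamido pyridine. In a functional assay on K562 cells (Homo sapiens) for inhibition, read by MTT assay, with a stated time of 48 h (a lower number here means a stronger inhibitor, a higher number a weaker inhibitor), compound 1 gives 8980 nM. Compound 2 `O=C(Nc1ccc(-c2cn([C@@H]3CN[C@H](C(=O)Nc4ccc(Cl)c(C(F)(F)F)c4)C3)nn2)cn1)C1CC1` carries the same head group with cyclopropyl in place of methyl on a carbonyl carbon. In this assay compound 2 gives 8770 nM, and the step of a 1.0-fold lower number from compound 1 to compound 2 (0.01 log units; within the scatter) shows that the exchange made no difference that can be told from noise.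

Compound 3 `CC(=O)Nc1nc2ccc(-c3cn([C@@H]4CN[C@H](C(=O)Nc5ccc(Cl)c(C(F)(F)F)c5)C4)nn3)nc2s1` has the acetamido group on a different core; the difference between the two cores is not broken down here. In this assay compound 3 gives 10000 nM, which lies within the scatter of both compound 1 and compound 2.

Compound 4 `O=C(Nc1nc2ccc(-c3cn([C@@H]4CN[C@H](C(=O)Nc5ccc(Cl)c(C(F)(F)F)c5)C4)nn3)nc2s1)C1CC1` has not been measured. It differs from compound 3 by cyclopropyl in place of methyl on a carbonyl carbon, and the place of the change is the same as in the pair of compound 1 and compound 2, so this is the same change applied to the other core. Going by the values given here, the only precedent for it is the step of a 1.0-fold lower number from compound 1 to compound 2 (0.01 log units; within the scatter), which sat within the scatter. Among the compounds with values here, on that basis the expected step from compound 3 to compound 4 is a 1.0-fold lower number from compound 3 to compound 4 (0.01 log units; within the scatter), essentially flat, because the sole prior instance a 1.0-fold lower number from compound 1 to compound 2 (0.01 log units; within the scatter) showed nothing. Compound 4 is therefore estimated to give about 9800 nM in this assay, with a likely range from 5000 nM to 20000 nM.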

Compound 4, half-maximal inhibitory concentration: 16200 nM
Estimate against measurement, compound 4: 1.7-fold (0.22 log units) below; the measured number falls inside the stated range.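

In this assay, putting cyclopropyl in place of methyl on the carbonyl carbon of the core of compound 3 gives a 1.6-fold higher number from compound 3 to compound 4 (0.21 log units; within the scatter), so on this core too the exchange cannot be told from noise. Set beside the same exchange on the core of compound 1, the new step does not stand apart from the earlier one, and the flat result holds on both cores: the same change on two cores in this assay, a 1.0-fold lower number (0.01 log units; within the scatter) from compound 1 to compound 2 and a 1.6-fold higher number (0.21 log units; within the scatter) from compound 3 to compound 4, 1.7-fold (0.22 log units) apart, within the scatter of two such steps. Going by these compounds alone, this supports carrying the change from one core to the other without a detectable shift in this assay, but it rests on only two pairs and does not show that the change would stay flat on any further core, or that the two cores respond identically within the scatter.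

All four compounds shown carry either acetamido or (cyclopropylcarbonyl)amino on the head group, so it remains open whether a longer chain on the carbonyl carbon, a free amine in place of the amide, or a carboxylic acid would move the number beyond the scatter. From the compounds shown here alone, the chloro and trifluoromethyl substituted anilide is the same throughout, so its part in these values also remains open.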